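The source may report more compounds than this note shows. Statements on the series, on what has been measured and on what is new or still open speak of the compounds shown alone.

Working notes on the series. Compound 1 `Cc1nc2c(c(-c3cc(F)c4c(c3C)CCCO4)c1[C@H](OC(C)(C)C)C(=O)O)CN(CCCc1ccccc1F)CC2` is measured in an ADME assay on MT2 cells (Homo sapiens) for cytotoxicity, read by XTT assay, with a stated time of 4 days (on this read-out higher numbers stand for lower toxicity in this test and lower numbers for higher toxicity in this test), only as a limit of the assay, not a number: compound 1 gives > 40000 nM. Compound 2 `Cc1ccc(-c2c3c(nc(C)c2[C@H](OC(C)(C)C)C(=O)O)CCN(c2ccc(-c4ccccc4)cc2)C3)cc1` likewise gives, as a limit in this assay, > 40000 nM. Both values shown sit at the limit of > 40000 nM in this assay, at which 2 of the 2 values shown sit, so compound 1 stands at the limit with no number to place it against any other compound. Compound 3 `Cc1nc2c(c(-c3cc(F)c4c(c3C)CCCO4)c1[C@H](OC(C)(C)C)C(=O)O)CN(CCCc1ccncc1)CC2` differs from compound 1 by pyridin-4-yl in place of 2-fluorophenyl on a saturated chain carbon, three bonds along the chain from an amine nitrogen in a ring. Among the compounds with values here, no measured step is available; the expected step is none beyond the scatter, a step that the limit leaves unreadable from compound 1 to compound 3, with compound 3 expected to return a limit again. Compound 3 is estimated at 60000 nM, in a range from 30000 nM to 120000 nM.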

Compound 3, half-maximal cytotoxic concentration: > 40000 nM
Compound 3: a limit, no number; the forecaster's own chance of this, stated with the estimate: 85%; the middle value is on the limit's open side.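

Within the data shown here, no step from compound 1 to compound 3 can be read, since compound 3 also returns a limit rather than a number: the limit of > 40000 nM in this assay, at which 3 of the 3 values shown sit. The compounds shown leave open whether pyridin-4-yl in place of 2-fluorophenyl changes this read-out at all.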